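One Stereocentre Drawn: What to Expect of Compound 3

The source may hold more compounds than are shown below. What is called first, only, known or untested is meant among the compounds shown, and "the series" means these compounds.

Values measured in a functional assay on HCT-116 cells (Homo sapiens) for cytotoxicity, read by MTT assay, with a stated time of 72 h (on this read-out higher numbers stand for weaker inhibition and lower numbers for stronger inhibition), so far
- compound 1 `CC1(C)OCC(Cn2cc(Cn3c4c(c5ccccc53)C(=O)c3c[n+]([O-])c5ccccc5c3C4=O)nn2)O1` gives 70 nM
- compound 2 `O=C1c2c[n+]([O-])c3ccccc3c2C(=O)c2c1c1ccccc1n2CCCCN1CCNCC1` gives 700 nM

Of these two compounds, compound 1 (70 nM) has the lower number and so the stronger inhibition. Compound 2 (700 nM) lies above it by a gap beyond the scatter.

Compound 3 `CC1(C)OC[C@@H](Cn2cc(Cn3c4c(c5ccccc53)C(=O)c3c[n+]([O-])c5ccccc5c3C4=O)nn2)O1` has not yet been measured. It differs from compound 1 only as follows (the two compounds have the same atoms and bonds; at least one stereo element is drawn with a configuration in one of them and without one in the other: 1 of 1 stereo elements differ; a stereocentre at a saturated ring carbon is drawn without a configuration in compound 1 and R in compound 3): a stereocentre at a saturated ring carbon is drawn without a configuration in compound 1 and R in compound 3.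

Among the measured compounds shown here, no measured pair shows how a change of this kind behaves in this assay (short of direct evidence, the comparison rests on compound 1 alone). The expected step is no change at the digits printed from compound 1 to compound 3 (within the scatter) and none beyond the scatter is expected. Compound 3 is estimated at 70 nM with an expected range from 30 nM to 160 nM in the coming measurement.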

Compound 3, half-maximal inhibitory concentration: 340 nM
Beside the measured number, compound 3's estimate is 4.9-fold (0.69 log units) below it; measured number outside the range, above it.
By their numbers in this assay, from the lowest: compound 1; then compound 3; then compound 2.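

In this assay, the saturated ring carbon proves not to be a silent position: with atoms and bonds unchanged, drawing it R comes with a 4.9-fold higher number from compound 1 to compound 3 (0.69 log units; beyond the scatter). Compound 1 and compound 2 differ in more than one place, so they could not show that the drawn configuration at this stereocentre alone can separate two numbers beyond the scatter. The pair offers only one difference to point to: the fact that one of compounds 1 and 3 is drawn with a defined configuration and the other without, at the place where they differ.

From the compounds shown here alone, what the undefined drawing of compound 1 stands for in the tested sample remains open, as does how a compound drawn S at this carbon would read. Also open, going by these compounds, is how this assay would respond to an open-chain diol or an amine in place of the saturated ring that carries the stereocentre.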